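A few compounds are considered here, and "the series" means these few. Any claim that something is new, unique, unknown or untested is made for them only; others in the source may bear on it.

Three compounds are in view: compound 1 `CCOC(=O)c1cc(-c2cc(OC)c(OC)c(OC)c2)c(-c2cccc(Br)c2)s1`, compound 2 `COc1ccc(-c2sccc2-c2cc(OC)c(OC)c(OC)c2)cc1` and compound 3 `COc1cc(-c2ccsc2-c2cccc(Br)c2)cc(OC)c1OC`. Going by the values given here, in a functional assay on SGC-7901 cells (Homo sapiens) for antiproliferative activity, read by MTT assay, with a stated time of 72 h (a lower number here means a stronger inhibitor, a higher number a weaker inhibitor), compound 2 gives 5470 nM, the only exact number so far. Compound 1 reads > 100000 nM, which is a limit of the assay and not a number. Compound 3 has not yet been measured. It departs from compound 2 at one place, on an aromatic carbon next to the ring sulfur, where 3-bromophenyl stands in place of 4-methoxyphenyl: 3-bromophenyl in place of 4-methoxyphenyl on an aromatic carbon. Among the compounds with values here, no measured step isolates this change, so the expectation rests on thin ground: the only measured compound bearing 3-bromophenyl is compound 1, with its limit of > 100000 nM. A loss of potency beyond the scatter is expected in this assay, an estimated 4.6-fold higher number from compound 2 to compound 3 (0.66 log units; beyond the scatter). Compound 3 is expected to give about 25000 nM, with an estimated range of 6000 nM to 100000 nM.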

Compound 3, half-maximal inhibitory concentration: 46100 nM
The estimate for compound 3 lay 1.8-fold (0.27 log units) below the measured number; measured number inside the range.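

In this assay the exchange of 4-methoxyphenyl for 3-bromophenyl on an aromatic carbon next to the ring sulfur now has a measured size: an 8.4-fold higher number from compound 2 to compound 3 (0.93 log units; beyond the scatter) on the shared core. Hydrogen in place of ethoxycarbonyl on an aromatic carbon, with 3-bromophenyl kept, gives an at least 2.1-fold lower number from compound 1 to compound 3 (0.33 log units; beyond the scatter) in this assay and so shows that compound 3 retains measurable activity once ethoxycarbonyl is gone. Compound 1 reads > 100000 nM as a limit of the assay and not a number, so the full size of that second step cannot be read: the limit of > 100000 nM in this assay, at which 1 of the 3 values shown sits.

Going by these compounds, whether the loss on going to 3-bromophenyl follows from the bromine atom or from its place on the phenyl ring stays open. On these data alone, how 4-bromophenyl, 3-methoxyphenyl or an aminophenyl group would read on this carbon also remains open.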